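Ring size at the amine: pyrrolidine to piperidine

A few compounds are considered here, and "the series" means these few. Any claim that something is new, unique, unknown or untested is made for them only; others in the source may bear on it.

The study pairs two cores. Compound 1 `CNC(=O)c1cc(Oc2ccc(Nc3nccc(N4CCCC4)n3)cc2)ccn1` and compound 3 `CNC(=O)c1cc(Oc2ccc(Nc3nccc(N4CCCCC4)n3)cc2)ccn1` share one core; compound 2 `CN(c1ccc(Oc2ncnc3sccc23)cc1)c1nccc(N2CCCC2)n1` and compound 4 `CN(c1ccc(Oc2ncnc3sccc23)cc1)c1nccc(N2CCCCC2)n1` share another. The difference between the two cores is not broken down here. In a functional assay on A549 cells (Homo sapiens) for inhibition, read by MTT assay, with a stated time of 72 h, tested at 20 uM (a higher number here means more inhibition at the concentration tested (going by the name of the read-out), a lower number less inhibition), compound 1 gives 59.6%, compound 3 gives 63.4%, and compound 2 gives 55.5%. The change from compound 1 to compound 3 is piperidin-1-yl in place of pyrrolidin-1-yl on an aromatic carbon, and its step, a number 3.8 percentage points higher from compound 1 to compound 3 (within the scatter), stays within the scatter, so no order between these two compounds can be read from it. The same change is made from compound 2 to compound 4: piperidin-1-yl in place of pyrrolidin-1-yl on an aromatic carbon. Among the compounds with values here, since the change is the same and the only measured instance of it moved the read-out in this assay by no more than the scatter, compound 4 is expected to stay close to compound 2, with the step estimated as a number 3.5 percentage points higher from compound 2 to compound 4 (within the scatter). On that basis compound 4 is estimated at 59% in this assay, with an expected range from 46% to 72%.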

Compound 4, a percentage reported as inhibition, at one concentration (the size of the read-out at that concentration, not a potency): 51.9%
Estimate against measurement, compound 4: 7.1 percentage points above, and the stated range covers the measured number.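

Replacing pyrrolidin-1-yl with piperidin-1-yl on the core of compound 2 gives, in this assay, a number 3.6 percentage points lower from compound 2 to compound 4 (within the scatter). Set beside the same change on the core of compound 1, the new step does not differ from the earlier one: the same change on two cores in this assay, a number 3.8 percentage points higher (within the scatter) from compound 1 to compound 3 and a number 3.6 percentage points lower (within the scatter) from compound 2 to compound 4, 7.4 percentage points apart, within the scatter of two such steps. The change therefore stays within the scatter on both cores, which is as far as carrying it across goes here; the direction of neither step can be read, and two pairs tested at one concentration show nothing about potency or about how the change would behave on any other core.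

The compounds shown leave open whether a ring amine with a second hetero atom, such as morpholine or piperazine, or an open-chain amine such as dimethylamino, would move the read-out beyond the scatter at this place. On these data alone, what a smaller ring such as azetidine would do there also remains open.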